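The source may report more compounds than this note shows. Statements on the series, on what has been measured and on what is new or still open speak of the compounds shown alone.

In an ADME assay on microsomes from liver (Rattus norvegicus) for metabolic stability (a lower number here means that the compound disappears faster, a higher number that the compound lasts longer), three compounds have been measured:
compound 1 `CC#C[C@@H](Cc1nnn[nH]1)c1ccc(OCc2ccc3sc(F)c(-c4ccccc4C)c3c2)cc1` gives 0.367 h
compound 2 `CC#C[C@@H](Cc1nnn[nH]1)c1ccc(OCc2ccc3sc(C)c(-c4ccc(OCCOC)cc4C)c3c2)cc1` gives 0.117 h
compound 3 `CC#C[C@@H](Cc1nnn[nH]1)c1ccc(OCc2ccc3sc(I)c(-c4ccccc4C)c3c2)cc1` gives 0.483 h

Compound 3 lies within the scatter of compound 1, and both numbers stand clearly above that of compound 2. Compound 4 `CC#C[C@@H](Cc1nnn[nH]1)c1ccc(OCc2ccc3sc(C)c(-c4ccccc4C)c3c2)cc1` follows from compound 3 by one change methyl in place of iodo on an aromatic carbon with methyl in place of iodo on an aromatic carbon. For the measured compounds named here, the one measured step at this place, a 1.3-fold higher number from compound 1 to compound 3 (0.12 log units; within the scatter) for iodo in place of fluoro, stays within the scatter, but no such step to methyl has been measured. Compound 2 at 0.117 h also carries this methyl but has a further chain, so it pulls the expectation only slightly downward. The expected step of a 1.6-fold lower number from compound 3 to compound 4 (0.21 log units; within the scatter) is a small fall that stays within the scatter. Compound 4 is estimated at 0.3 h with 0.13 h to 0.65 h as its expected range.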

Compound 4, half-life: 0.483 h
Compound 4: middle estimate off by 1.6-fold (0.21 log units), on the low side; low and high end bracket the measured number.
By their numbers in this assay, from the lowest: compound 2; then compounds 1, 3 and 4 (each within the scatter of the next).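

In this assay, methyl at the position next to the ring sulfur reads the same as iodo (no change at the digits printed from compound 3 to compound 4 (within the scatter)) and fluoro (a 1.3-fold higher number from compound 1 to compound 4 (0.12 log units; within the scatter)), so all three groups at this position fall within the scatter. For the compounds shown here, the one step beyond the scatter lies elsewhere, with hydrogen in place of 2-methoxyethoxy on an aromatic carbon (a 4.1-fold higher number from compound 2 to compound 4 (0.62 log units; beyond the scatter)). Nothing available explains either finding. Going by these compounds, whether an amine, a carboxylic acid or a longer chain at the position next to the ring sulfur would also leave the half-life in place stays open. So does whether 2-methoxyethoxy would give a similar step alongside fluoro or iodo.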